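Swapping an aryl group for bromo on the shared core

The source may hold more compounds than are shown below. What is called first, only, known or untested is meant among the compounds shown, and "the series" means these compounds.

Compound 1 `O=C(NO)c1ccc(/C=C/c2ccnc(-c3cccc(CO)c3)c2)cc1` gives 1740 nM
Compound 2 `Cc1ccc(-c2cc(/C=C/c3ccc(C(=O)NO)cc3)ccn2)cc1` gives 1910 nM

Among the compounds with values here, in a functional assay on MGC-803 cells (Homo sapiens) for antiproliferative activity, read by CellTiter-Glo, with a stated time of 72 h (a higher number here means a weaker inhibitor, a lower number a stronger inhibitor), compound 2 stands level with compound 1, the only other measured compound, within the usual scatter. Compound 3 `O=C(NO)c1ccc(/C=C/c2ccnc(Br)c2)cc1` carries bromo in place of 4-methylphenyl on an aromatic carbon. Within the data shown here, the single measured step (a 1.1-fold higher number from compound 1 to compound 2 (0.04 log units; within the scatter)) only exchanged one substituted phenyl for another, so it offers little guidance on losing the whole 4-methylphenyl group. The direction of the change is uncertain. A modest step towards a higher number is expected (a 1.3-fold higher number from compound 2 to compound 3 (0.12 log units; within the scatter)). Compound 3 is estimated at 2500 nM (range 700 nM to 9000 nM).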

Compound 3, half-maximal inhibitory concentration: > 10000 nM
Compound 3 was reported as a limit; the forecaster's own chance of this, stated with the estimate: 5%; middle value at least 4.0-fold (0.60 log units) from the limit.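

In this assay compound 3 gives > 10000 nM, which is a limit of the assay and not a number. At this position, next to the ring nitrogen, exchanging one substituted phenyl for another changed little, but losing the phenyl ring for bromo gives an at least 5.2-fold higher number from compound 2 to compound 3 (0.71 log units; beyond the scatter), and likewise an at least 5.7-fold higher number from compound 1 to compound 3 (0.75 log units; beyond the scatter). Among these compounds, then, only those with a substituted phenyl here give a measurable value.

Going by these compounds, it stays open whether a ring itself is needed here, or whether an amine or a short alkyl chain in place of bromo would restore activity.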